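Trimethoxyphenyl in Place of Styryl on the Saturated Ring Carbon

The source may report more compounds than this note shows. Statements on the series, on what has been measured and on what is new or still open speak of the compounds shown alone.

Compound 1 `Cc1cc(O)c(C2=NN(c3ccc(S(N)(=O)=O)cc3)C(c3ccccc3Cl)C2)cc1Cl`: 3310 nM
Compound 2 `Cc1cc(O)c(C2=NN(c3ccc(S(N)(=O)=O)cc3)C(/C=C/c3ccccc3)C2)cc1Cl`: 22100 nM

Of the compounds shown here, two sharing one core have been measured in a functional assay on COLO 205 cells (Homo sapiens) for antiproliferative activity, with a stated time of 48 h; a higher number here means a weaker inhibitor of growth, a lower number a stronger inhibitor of growth. Compound 1 gives 3310 nM, and compound 2 gives 22100 nM, the higher of the two numbers; the step of a 6.7-fold higher number from compound 1 to compound 2 (0.82 log units; beyond the scatter) separates them. Compound 3 `COc1ccc(C2CC(c3cc(Cl)c(C)cc3O)=NN2c2ccc(S(N)(=O)=O)cc2)c(OC)c1OC` differs from compound 2 at the same saturated ring carbon: 2,3,4-trimethoxyphenyl in place of 2-phenylethenyl on a saturated ring carbon.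

Within the data shown here, only one measured step bears on this change. It shows that replacing an aromatic ring on that carbon with the 2-phenylethenyl group moved the number upward by a 6.7-fold higher number from compound 1 to compound 2 (0.82 log units; beyond the scatter). Compound 3 undoes that replacement, restoring an aromatic ring there, though a 2,3,4-trimethoxyphenyl rather than the 2-chlorophenyl of compound 1. Among the measured compounds shown here, no measured pair tells how the trimethoxy substitution itself matters, so the expectation rests on the return to an aryl group. Compound 3 is therefore expected to move back toward the value of compound 1, a step of a 4.4-fold lower number from compound 2 to compound 3 (0.65 log units; beyond the scatter), and is estimated at 5000 nM, within the range 1500 nM to 20000 nM.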

Compound 3, concentration for total growth inhibition: 3090 nM
For compound 3 the middle estimate is 1.6-fold (0.21 log units) above the measured one; the measured number falls inside the stated range.
By their numbers in this assay, from the lowest: compounds 3 and 1 (each within the scatter of the next); then compound 2.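

In this assay the change to 2,3,4-trimethoxyphenyl gives a 7.2-fold lower number from compound 2 to compound 3 (0.85 log units; beyond the scatter), so the effect seen earlier is not confined to the 2-chlorophenyl group: a second, differently substituted phenyl ring on this saturated ring carbon also stands well apart from 2-phenylethenyl. The two aryl groups themselves cannot be told apart in this assay, with a 1.1-fold lower number from compound 1 to compound 3 (0.03 log units; within the scatter), even though 2,3,4-trimethoxyphenyl carries three methoxy groups and 2-chlorophenyl carries a single chlorine. Among these three compounds, then, the clear division at this position lies between the two groups with the ring bound directly to the saturated carbon and the one with the ring held on a two-carbon alkene link, and nothing given accounts for that division.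

Among these compounds, with 2-phenylethenyl as the only non-aryl group, it remains open whether the saturated analogue, 2-phenylethyl, or a cyclohexyl ring on the same carbon would fall with compound 2 or with compound 1. Also open is how an unsubstituted phenyl or a phenyl bearing a single methoxy group would compare, since the substituents on the two aryl rings shown differ in both kind and number.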